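Amide nitrogen substituent and microsomal clearance, compound 4

The source may report more compounds than this note shows. Statements on the series, on what has been measured and on what is new or still open speak of the compounds shown alone.

Measured values in an ADME assay on liver for metabolic stability, with Liver microsome (Homo sapiens) as the target, using microsomes; on this read-out higher numbers stand for fast clearance and lower numbers for slow clearance:
compound 1 `O=C(N[C@H]1CCOC[C@@H]1O)c1cn(Cc2ccc(-n3cccn3)cc2)c2cccnc12`: < 8 mL/min/kg, a limit of the assay rather than a number
compound 2 `O=C(NC[C@@H]1CCCO1)c1cn(Cc2ccc(-n3cccn3)cc2)c2cccnc12`: 133 mL/min/kg
compound 3 `O=C(N[C@H]1CCCC[C@@H]1O)c1cn(Cc2ccc(-n3cccn3)cc2)c2cccnc12`: 59 mL/min/kg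

Compound 3 has the lowest of the two measured numbers in this assay; the nearest is compound 2, with a 2.3-fold lower number from compound 2 to compound 3 (0.35 log units; beyond the scatter). Compound 1 stands at the limit of < 8 mL/min/kg in this assay, at which 1 of the 3 values shown sits, so the step of an at least 7.3-fold higher number from compound 1 to compound 3 (0.86 log units; beyond the scatter) is known only as a lower bound.

Compound 4 `O=C(NCC1(O)CCC1)c1cn(Cc2ccc(-n3cccn3)cc2)c2cccnc12` carries (1-hydroxycyclobutyl)methyl in place of 2-hydroxycyclohexyl on an amide-type nitrogen. All three measured steps change the group on the amide-type nitrogen, so all bear on it: an at least 16-fold higher number from compound 1 to compound 2 (1.22 log units; beyond the scatter), an at least 7.3-fold higher number from compound 1 to compound 3 (0.86 log units; beyond the scatter) and a 2.3-fold lower number from compound 2 to compound 3 (0.35 log units; beyond the scatter). None of them, however, brings in the (1-hydroxycyclobutyl)methyl group, and the closest precedents, compound 2 and compound 3, lie within a modest step of each other in this assay.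

The expected step in this assay is therefore a 1.5-fold lower number from compound 3 to compound 4 (0.17 log units; within the scatter), small and toward lower numbers, close to the scatter. Compound 4 is estimated at 40 mL/min/kg, with a range from 15 mL/min/kg to 100 mL/min/kg.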

Compound 4, clearance: 17 mL/min/kg
Compound 4: middle estimate off by 2.4-fold (0.37 log units), on the high side; low and high end bracket the measured number.
By their numbers in this assay, from the lowest: compound 4; then compound 3; then compound 2. At a limit, below all of these: compound 1.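

In this assay, the step of a 3.5-fold lower number from compound 3 to compound 4 (0.54 log units; beyond the scatter) shows that the carbocyclic hydroxylated groups on the amide-type nitrogen are not tied to the number seen with 2-hydroxycyclohexyl, although 2-hydroxycyclohexyl and (1-hydroxycyclobutyl)methyl have the same hydrogen-bond donor and acceptor counts. The step of a 7.8-fold lower number from compound 2 to compound 4 (0.89 log units; beyond the scatter) places compound 4 well clear of the (oxolan-2-yl)methyl group of compound 2, which keeps the highest number of the series. Compound 1 remains at a limit of the assay, so the step of an at least 2.1-fold higher number from compound 1 to compound 4 (0.32 log units; beyond the scatter) is only a lower bound and 3-hydroxyoxan-4-yl stays ahead of the new group: the limit of < 8 mL/min/kg in this assay, at which 1 of the 4 values shown sits.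

Ring size, the chain carbon and the placement of the hydroxyl all change together in this step, so their shares cannot be separated. From the compounds shown here alone, how 2-hydroxycyclobutyl, (1-hydroxycyclopentyl)methyl or (1-aminocyclobutyl)methyl would read at this position remains open.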